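Replacing phenethyl on sulfur: compound 3 to compound 4

The source may report more compounds than this note shows. Statements on the series, on what has been measured and on what is new or still open speak of the compounds shown alone.

Compound 1 `COc1ccc(SCc2ccc(C(=O)Nc3ccccc3N)cc2)cc1` gives 2170 nM
Compound 2 `CCc1ccc(SCc2ccc(C(=O)Nc3ccccc3N)cc2)cc1` gives 1750 nM
Compound 3 `Nc1ccccc1NC(=O)c1ccc(CSCCc2ccccc2)cc1` gives 4880 nM

In a functional assay on SMMC-7721 cells (Homo sapiens) for antiproliferative activity, read by CCK-8 assay, with a stated time of 72 h (a lower number here means a stronger inhibitor, a higher number a weaker inhibitor), compound 3 has the highest of the three numbers, and its gaps to both others lie beyond the scatter. Compound 4 `Cc1cc(C)cc(SCc2ccc(C(=O)Nc3ccccc3N)cc2)c1` carries 3,5-dimethylphenyl in place of phenethyl on a sulfur and is not yet measured. Two modest steps bear on this change when read in reverse: a 2.2-fold higher number from compound 1 to compound 3 (0.35 log units; beyond the scatter) and a 2.8-fold higher number from compound 2 to compound 3 (0.45 log units; beyond the scatter). Between the two aryl compounds, a 1.2-fold lower number from compound 1 to compound 2 (0.09 log units; within the scatter). Among the compounds with values here, no measured compound carries 3,5-dimethylphenyl, so a modest fall of similar size is expected in this assay. The expected change is a 2.6-fold lower number from compound 3 to compound 4 (0.41 log units; beyond the scatter). Compound 4 is estimated at 1900 nM, with an expected range of 950 nM to 3800 nM.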

Compound 4, half-maximal inhibitory concentration: 2760 nM
Compound 4: middle estimate off by 1.5-fold (0.16 log units), on the low side; the measured number falls inside the stated range.
By their numbers in this assay, from the lowest: compounds 2, 1, 4 and 3 (each within the scatter of the next, the first and the last beyond it).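

In this assay the change to 3,5-dimethylphenyl gives a step within the scatter (a 1.8-fold lower number from compound 3 to compound 4 (0.25 log units; within the scatter)), so the separation from phenethyl seen for the two earlier aryl groups does not hold for compound 4. Nor does 3,5-dimethylphenyl separate from the other aryl groups on the sulfur (a 1.6-fold higher number from compound 2 to compound 4 (0.20 log units; within the scatter); a 1.3-fold higher number from compound 1 to compound 4 (0.10 log units; within the scatter)). No measurement at hand offers an explanation for these results.

Going by these compounds, whether a longer chain on the sulfur, or an amine or a carboxylic acid on the aromatic ring, would move the number beyond the scatter remains open.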